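The source may hold more compounds than are shown below. What is called first, only, known or untested is meant among the compounds shown, and "the series" means these compounds.

Working notes on the series. In a functional assay on A549 cells (Homo sapiens) for antiproliferative activity, read by MTT assay, with a stated time of 24 h (on this read-out higher numbers stand for weaker inhibition and lower numbers for stronger inhibition), compound 1 `COc1cc(/C=C/C(=O)c2cc(-c3cc(OC)c(OC)c(OC)c3)n3nc(-c4ccccc4)cc3n2)cc(OC)c1OC` gives 25900 nM, the highest of the three numbers in hand. Compound 2 `COc1ccc(-c2cc(C(=O)/C=C/c3cc(OC)c(OC)c(OC)c3)nc3cc(-c4ccccc4)nn23)cc1OC` gives 15400 nM in this assay, and compound 3 `COc1ccc(-c2cc(/C=C/C(=O)c3ccccc3)nc3cc(-c4ccccc4)nn23)cc1OC` gives 10700 nM. Within the data shown here, the one measured step of this kind, a 1.7-fold lower number from compound 1 to compound 2 (0.23 log units; within the scatter), concerned the other trimethoxyphenyl group. Compound 4 `COc1ccc(/C=C/C(=O)c2cc(-c3cc(OC)c(OC)c(OC)c3)n3nc(-c4ccccc4)cc3n2)cc1OC` differs from compound 1 by hydrogen in place of methoxy on an aromatic carbon. Among the measured compounds shown here, the only step that bears on it is the one from compound 1 to compound 2, which stayed within the scatter, so no movement beyond the scatter is expected here either, with at most a slight lowering. Compound 4 is therefore expected to show a 1.4-fold lower number from compound 1 to compound 4 (0.16 log units; within the scatter), giving an estimate of 18000 nM within a range of 8000 nM to 40000 nM.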

Compound 4, half-maximal inhibitory concentration: 20500 nM
Compound 4: middle estimate off by 1.1-fold (0.06 log units), on the low side; the measured number falls inside the stated range.
By their numbers in this assay, from the lowest: compounds 3, 2, 4 and 1 (each within the scatter of the next, the first and the last beyond it).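

In this assay, going from 3,4,5-trimethoxyphenyl to 3,4-dimethoxyphenyl at this group gives a 1.3-fold lower number from compound 1 to compound 4 (0.10 log units; within the scatter), so this change stays within the scatter here, as it did at the other trimethoxyphenyl group with a 1.7-fold lower number from compound 1 to compound 2 (0.23 log units; within the scatter). The change has now been read at both trimethoxyphenyl groups of compound 1, and neither step goes beyond the scatter. No evidence bears on this result.

On these data alone, whether a hydroxyl, an amine or a fluorine at this place would move the number beyond the scatter remains open. As far as these compounds go, the effect of removing both of the other methoxy groups from this ring also remains open.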